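This account rests on a few compounds, and the source may have more. Where it says the series, first, only, none or still open, it means among the compounds named here.

Working notes on the series. Three compounds sharing one core are measured in an ADME assay on L929 cells (Mus musculus) for cytotoxicity, read by resazurin assay, with a stated time of 72 h; on this read-out lower numbers stand for stronger inhibition and higher numbers for weaker inhibition. Compound 1 `Nc1ccc(C(=O)/C=C/c2ccc3c(c2)B(O)OC3)cc1` gives > 10 ug/mL, which is a limit of the assay and not a number. Compound 2 `COc1ccc(C(=O)/C=C/c2ccc3c(c2)B(O)OC3)cc1` gives > 10 ug/mL, again a limit. Compound 3 `COc1ccc(C(=O)/C=C/c2ccc3c(c2)B(O)OC3)cc1OC` gives > 10 ug/mL, also a limit. The step that the two limits leave unreadable from compound 2 to compound 1 is amino in place of methoxy on an aromatic carbon, and the step that the two limits leave unreadable from compound 2 to compound 3 is methoxy in place of hydrogen on an aromatic carbon; with the limit of > 10 ug/mL in this assay, at which 3 of the 3 values shown sit, neither size can be read. Compound 4 `COc1cc(C(=O)/C=C/c2ccc3c(c2)B(O)OC3)ccc1N`, not yet measured, differs from compound 3 by amino in place of methoxy on an aromatic carbon: the same kind of change as from compound 2 to compound 1, here sitting ortho to a methoxy group as well as para to a large group. Because compound 1, compound 2 and compound 3 all sit at the limit of > 10 ug/mL in this assay, at which 3 of the 3 values shown sit, no readable step supports any shift. The expected step is therefore a step that the limit leaves unreadable from compound 3 to compound 4, a guess only. Compound 4 is expected near 20 ug/mL, between 7 ug/mL and 60 ug/mL, most likely again reported as a limit.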

Compound 4, half-maximal inhibitory concentration: 1.45 ug/mL
Estimate against measurement, compound 4: 14-fold (1.14 log units) above; the measured number lies below the stated range.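

In this assay, amino in place of methoxy, here ortho to a methoxy group, gives an at least 6.8-fold lower number from compound 3 to compound 4 (0.83 log units; beyond the scatter), and methoxy in place of hydrogen on the amino-bearing compound gives an at least 6.8-fold lower number from compound 1 to compound 4 (0.83 log units; beyond the scatter). Compound 4 is the only one of the four with a readable number, 1.45 ug/mL. These two steps show that amino and methoxy together fall below the limit, while neither step gives an exact size. They do not show that the amino change carries from one core to another, since the same change from compound 2 to compound 1 and the step from compound 2 to compound 3 cannot be read because of the limit: the limit of > 10 ug/mL in this assay, at which 3 of the 4 values shown sit.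

The compounds shown leave open whether a hydroxyl or an acetamide in place of the amino group would give a readable number. They also leave open whether an ethoxy group could stand in for the methoxy group of compound 4.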